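Changing the Aryl Tail: Half-Life Expected for Compound 3

The source may report more compounds than this note shows. Statements on the series, on what has been measured and on what is new or still open speak of the compounds shown alone.

Compound 1 `COc1cccc(CCOc2ccc(-c3c(C)nc(C)c([C@H](OC(C)(C)C)C(=O)O)c3N3CCC(C)(C)CC3)cc2)c1` in an ADME assay on microsomes from liver (Homo sapiens) for metabolic stability, read by LC-MS, tested at 0.5 uM; on this read-out lower numbers stand for a shorter-lived compound and higher numbers for a longer-lived compound: > 2 h, a limit of the assay rather than a number.
Compound 2 `Cc1nc(C)c([C@H](OC(C)(C)C)C(=O)O)c(N2CCC(C)(C)CC2)c1-c1ccc(OCCc2ccc(F)cc2F)cc1` in this assay: 1.08 h.

Among the measured compounds shown here, compound 2 holds the only plain number here; the other value sits at the limit of > 2 h in this assay, at which 1 of the 2 values shown sits. Compound 3 `Cc1nc(C)c([C@H](OC(C)(C)C)C(=O)O)c(N2CCC(C)(C)CC2)c1-c1ccc(OCCc2ccccn2)cc1` differs from compound 2 by pyridin-2-yl in place of 2,4-difluorophenyl on a saturated chain carbon, two bonds along the chain from an oxygen on an aromatic ring. For the measured compounds named here, one measured step touches the same place, an at least 1.8-fold lower number from compound 1 to compound 2 (0.26 log units; that floor lies within the scatter), and its floor lies within the scatter, so no clear direction can be drawn from it. For compound 3 the expected step is a 1.2-fold higher number from compound 2 to compound 3 (0.08 log units; within the scatter), essentially no change beyond the scatter. Compound 3 is estimated at 1.3 h, between 0.6 h and 3 h.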

Compound 3, half-life: 0.5 h
For compound 3 the middle estimate is 2.6-fold (0.41 log units) above the measured one; the whole stated range lies above it.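

In this assay, this position now shows a change beyond the scatter, with pyridin-2-yl in place of 2,4-difluorophenyl giving a 2.2-fold lower number from compound 2 to compound 3 (0.33 log units; beyond the scatter). Pyridin-2-yl in place of 3-methoxyphenyl gives an at least 4.0-fold lower number from compound 1 to compound 3 (0.60 log units; beyond the scatter), whereas the floor of the earlier step at this place stayed within the scatter. This larger step is only a floor, not a full size: the limit of > 2 h in this assay, at which 1 of the 3 values shown sits.

The compounds shown leave open whether the shorter half-life follows the ring nitrogen or the loss of both fluorines. A plain phenyl at this place, or pyridin-3-yl, would help separate these two readings.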